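Series notes: aryl change at the saturated ring carbon

The source may report more compounds than this note shows. Statements on the series, on what has been measured and on what is new or still open speak of the compounds shown alone.

Measured so far:
compound 1 `COc1cc(/C=C/C(=O)C2=C(/C=C/c3ccc(O)c(OC)c3)NC(=O)NC2c2ccccc2O)ccc1O` gives 80.9% in a functional assay, with a stated time of 20 min, tested at 20 uM; a higher number here means a stronger effect of the compound at the concentration tested, a lower number a weaker effect
compound 2 `COc1cc(/C=C/C(=O)C2=C(/C=C/c3ccc(O)c(OC)c3)NC(=O)NC2c2ccc(O)cc2)ccc1O` gives 80.1% in this assay

Compound 2 holds the lower of the two numbers in this assay, but the gap to compound 1, a number 0.8 percentage points lower from compound 1 to compound 2 (within the scatter), lies within the scatter, so the two cannot be ordered.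

Compound 3 `COc1cc(/C=C/C(=O)C2=C(/C=C/c3ccc(O)c(OC)c3)NC(=O)NC2c2cccc([N+](=O)[O-])c2)ccc1O` has not been measured. It differs from compound 2 by 3-nitrophenyl in place of 4-hydroxyphenyl on a saturated ring carbon. Among the compounds with values here, the one measured step at this saturated ring carbon, a number 0.8 percentage points lower from compound 1 to compound 2 (within the scatter), swaps the position of a hydroxyl on the aryl group and stays within the scatter; no measured step shows a 3-nitrophenyl at this place, so the change is only loosely informed. A step of no more than the scatter is expected, with some allowance for the untested group. For compound 3 the estimate is 75% in this assay, with a range from 55% to 90%, meaning an expected step of a number 5.1 percentage points lower from compound 2 to compound 3 (within the scatter).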

Compound 3, a percentage reported as activity, at one concentration (the size of the read-out at that concentration, not a potency): 33%
Estimate against measurement, compound 3: 42 percentage points above; the whole stated range lies above it.
By their numbers in this assay, from the lowest: compound 3; then compounds 2 and 1 (each within the scatter of the next).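

In this assay, 3-nitrophenyl in place of 4-hydroxyphenyl on the saturated ring carbon gives a number 47.1 percentage points lower from compound 2 to compound 3 (beyond the scatter), and 3-nitrophenyl in place of 2-hydroxyphenyl gives a number 47.9 percentage points lower from compound 1 to compound 3 (beyond the scatter). The earlier pair showed only that moving the hydroxyl around the aryl group made no readable difference, a number 0.8 percentage points lower from compound 1 to compound 2 (within the scatter), whereas these steps show that the read-out at this position does depend on which aryl group is present. No measurement at hand accounts for the drop.

The compounds shown do not separate the loss of the hydroxyl from the arrival of the nitro group, as both occur in the same change. A plain phenyl or an aminophenyl at this carbon would be needed to tell these two apart.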